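Does a 3-Fluorophenyl Group Wake an Inactive Series?

The source may report more compounds than this note shows. Statements on the series, on what has been measured and on what is new or still open speak of the compounds shown alone.

In a functional assay on ECa-109 cells for inhibition, with ECa-109 cell line (Homo sapiens) as the target, read by sulforhodamine B assay (a higher number here means a weaker inhibitor, a lower number a stronger inhibitor), compound 3 (`O=C1C=C(NC2CCCCC2)C(=O)c2c1nc1n2[C@H]2OC[C@@H](O)[C@H]2OC1`) reads > 16000 nM, which is a limit and not a number. Compound 2 (`O=C1C=C(N2CCC2)C(=O)c2c1nc1n2[C@H]2OC[C@@H](O)[C@H]2OC1`) reads > 16000 nM, also a limit. Compound 1 (`O=C1C=C(NCc2ccccc2)C(=O)c2c1nc1n2[C@H]2OC[C@@H](O)[C@H]2OC1`) reads > 8000 nM, again a limit. For the measured compounds named here, compound 3 therefore sits at the limit of > 16000 nM in this assay, at which 2 of the 3 values shown sit, and no measured compound in this set has yet given a true number.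

The next compound, compound 4 (`O=C1C=C(Nc2cccc(F)c2)C(=O)c2c1nc1n2[C@H]2OC[C@@H](O)[C@H]2OC1`), keeps the shared core and changes one group: 3-fluorophenyl in place of cyclohexyl on an amine nitrogen. In words, 3-fluorophenyl stands in place of cyclohexyl on an amine nitrogen.

Going by the values given here, two measured steps bear on this change: a step that the two limits leave unreadable from compound 1 to compound 3 and a step that the two limits leave unreadable from compound 2 to compound 3. Neither offers a size or a direction to carry over, so no step beyond the usual scatter is expected in this assay, and compound 4 is expected to remain a weak inhibitor. The estimate for compound 4 is 12000 nM, with an expected range from 3000 nM to 30000 nM. This estimate means an expected at least 1.3-fold lower number from compound 3 to compound 4 (0.12 log units; that floor lies within the scatter).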

Compound 4, half-maximal inhibitory concentration: 7030 nM
Estimate against measurement, compound 4: 1.7-fold (0.23 log units) above, and the stated range covers the measured number.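

In this assay, for the compounds shown here, compound 4 is the first compound here to give a true number rather than a limit, so this position on the double-bonded ring carbon can yield a readable result. Putting 3-fluorophenyl in place of cyclohexyl on the amine nitrogen gives a lower number that clears the usual scatter (an at least 2.2-fold lower number from compound 3 to compound 4 (0.35 log units; beyond the scatter)), and the change from azetidin-1-yl does the same (an at least 2.2-fold lower number from compound 2 to compound 4 (0.35 log units; beyond the scatter)). The change from benzyl is a different case: its floor stays within the scatter (an at least 1.1-fold lower number from compound 1 to compound 4 (0.05 log units; that floor lies within the scatter)), so no order can be claimed for that pair.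

The compounds shown leave open whether the fluorine or the aromatic ring itself accounts for the lower number. A plain phenyl on the same nitrogen would separate the two, and a chlorine or a methoxy group on that ring would show how much the ring's substituent matters.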